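A few compounds are considered here, and "the series" means these few. Any claim that something is new, unique, unknown or untested is made for them only; others in the source may bear on it.

Measured so far:
compound 1 `COc1ccc(-c2cn3cc(Br)nc(N)c3n2)cc1`: 24%
compound 2 `Nc1nc(-c2ccccc2)cn2cc(-c3ccccc3)nc12`: 23%

In an assay on cells for displacement of a labelled ligand from transmembrane domain-containing protein TMIGD3 (Homo sapiens), read by scintillation counting, with a stated time of 120 min, tested at 1 uM (a lower number here means less inhibition, a higher number more inhibition at the concentration tested (going by the name of the read-out)), compound 2 gives 23%, and compound 1 gives 24% in this assay, so the two sit within the scatter of each other and neither can be set above the other. Going by the values given here, no step between measured compounds that differ in one place is available. Compound 3 `COc1ccc(-c2cn3cc(-c4ccccc4)nc(N)c3n2)cc1` differs from compound 2 by methoxy in place of hydrogen on an aromatic carbon. Nothing measured here shows what such a change does, so the expected step from compound 2 to compound 3 in this assay is a number 2 percentage points higher from compound 2 to compound 3 (within the scatter), none beyond the scatter. Compound 3 is expected at 25%, between 10% and 42%.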

Compound 3, a percentage reported as inhibition, at one concentration (the size of the read-out at that concentration, not a potency): 27%
Estimate against measurement, compound 3: 2 percentage points below, within the range that was stated.
By their numbers in this assay, from the lowest: compounds 2, 1 and 3 (each within the scatter of the next).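

In this assay, methoxy in place of hydrogen, para to a large group, gives a number 4 percentage points higher from compound 2 to compound 3 (within the scatter) and phenyl in place of bromo on an aromatic carbon gives a number 3 percentage points higher from compound 1 to compound 3 (within the scatter) with both steps inside the scatter. Neither phenyl to 4-methoxyphenyl nor bromo to phenyl therefore produces a readable change in inhibition at the single concentration tested. No evidence on hand bears on this result.

From the compounds shown here alone, whether an amine, a carboxylic acid or a longer chain in the methoxy place would move the inhibition beyond the scatter remains open. The potency of these compounds also remains open.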